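The source may hold more compounds than are shown below. What is called first, only, known or untested is meant among the compounds shown, and "the series" means these compounds.

Compound 3 `CCCCCOC(=O)N1CCN(C(=O)[C@H](CCC(=O)O)NC(=O)c2cc(N3CCC(C(=O)N4CCCC4)CC3)nc(-c3ccccc3)n2)CC1` gives 0.0133 h in an in vivo ADME assay on the whole organism (strain Sprague-Dawley) for metabolic stability, with Rattus norvegicus as the target; a lower number here means that the compound disappears faster, a higher number that the compound lasts longer. Of the three compounds measured, compound 3 holds the second highest number: compound 2 `CCCCCOC(=O)N1CCN(C(=O)[C@H](CCC(=O)O)NC(=O)c2cc(N3CCC(COC)CC3)nc(-c3ccccc3)n2)CC1` gives 0.015 h, and a 1.1-fold lower number from compound 2 to compound 3 (0.05 log units; within the scatter). Compound 1 `CCCCCOC(=O)N1CCN(C(=O)[C@H](CCC(=O)O)NC(=O)c2cc(N3CCC(C(=O)NCC)CC3)nc(-c3ccccc3)n2)CC1` gives 0.005 h, and a 2.7-fold higher number from compound 1 to compound 3 (0.42 log units; beyond the scatter). Compound 4 `CCCCCOC(=O)N1CCN(C(=O)[C@H](CCC(=O)O)NC(=O)c2cc(N3CCC(C(N)=O)CC3)nc(-c3ccccc3)n2)CC1` differs from compound 3 in one place: amino in place of pyrrolidin-1-yl on a carbonyl carbon. For the measured compounds named here, two measured steps bear on this position on the saturated ring carbon, namely a 3.0-fold higher number from compound 1 to compound 2 (0.48 log units; beyond the scatter) and a 2.7-fold higher number from compound 1 to compound 3 (0.42 log units; beyond the scatter), both modest and beyond the scatter. Because a 2.7-fold higher number from compound 1 to compound 3 (0.42 log units; beyond the scatter) rose when ethylamino gave way to pyrrolidin-1-yl, the return to a group with a hydrogen-bond donor is expected to lower the number modestly, a 1.7-fold lower number from compound 3 to compound 4 (0.22 log units; within the scatter). For compound 4 the half-life is estimated at 0.008 h, within a range from 0.004 h to 0.02 h.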

Compound 4, half-life: 0.00667 h
For compound 4 the middle estimate is 1.2-fold (0.08 log units) above the measured one; low and high end bracket the measured number.
By their numbers in this assay, from the lowest: compounds 1, 4, 3 and 2 (each within the scatter of the next, the first and the last beyond it).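

In this assay the plain carbamoyl cannot be told apart from either neighbouring amide: a 2.0-fold lower number from compound 3 to compound 4 (0.30 log units; within the scatter), and a 1.3-fold higher number from compound 1 to compound 4 (0.13 log units; within the scatter). Removing the pyrrolidin-1-yl ring or the ethyl therefore has no readable effect here, even though compound 1 and compound 3 differ beyond the scatter. Methoxymethyl still separates from this amide, with a 2.2-fold lower number from compound 2 to compound 4 (0.35 log units; beyond the scatter), although compound 3 goes against any simple split between amides and methoxymethyl.

Nothing available explains these differences. Still open, going by these compounds, is how a carboxylic acid or an amine on the saturated ring carbon would change the half-life.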